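Bromine Added Where Both Parents Gave Only a Limit

The compounds below may be only part of what the source reports. "The series", "measured", "known", "first", "only" and "open" are said of these compounds alone.

Compound 1 `CC(C)n1ncc2c(C(=O)NC3CCCC3)cccc21` and compound 2 `CC(C)n1ncc2c(C(=O)NCc3cn(-c4ccccc4)nn3)cccc21` share one core and differ in the group attached to it. In a functional assay on HepG2 cells (Homo sapiens) for inhibition, read by MTT assay, with a stated time of 72 h (on this read-out higher numbers stand for weaker inhibition and lower numbers for stronger inhibition), compound 1 gives only a limit, > 40000 nM. Compound 2 likewise gives only a limit in this assay, > 40000 nM. Compound 2 thus sits at the limit of > 40000 nM in this assay, at which 2 of the 2 values shown sit. Compound 3 `CC(C)n1ncc2c(C(=O)NCc3cn(-c4cccc(Br)c4)nn3)cccc21` carries the change (bromo in place of hydrogen on an aromatic carbon), bromo in place of hydrogen on an aromatic carbon. Among the compounds with values here, no measured step guides this change, so the expected step is a number no higher from compound 2 to compound 3 (the limit leaves the size open), with no direction beyond the scatter. Compound 3 is estimated at 40000 nM, in a range from 15000 nM to 100000 nM.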

Compound 3, half-maximal inhibitory concentration: > 40000 nM
Compound 3: no number, only a limit; the forecaster's own chance of this, stated with the estimate: 75%; the middle value lies on the limit itself.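

In this assay, within the data shown here, compound 3 gives only a limit, > 40000 nM, so no step from compound 2 to compound 3 can be read. The compounds shown leave open what bromo in place of hydrogen does to inhibition in this assay.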